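A few compounds are considered here, and "the series" means these few. Any claim that something is new, unique, unknown or untested is made for them only; others in the source may bear on it.

Compound 1 `CC(C(=O)NCc1ccc(C(F)(F)F)cc1N1CCC(Cc2ccccc2)(N(C)C)CC1)c1ccc(NS(C)(=O)=O)c(F)c1`: 3.79 nM
Compound 2 `CN(C)C1(Cc2ccccc2)CCN(c2cc(C(F)(F)F)ccc2CNC(=O)Nc2ccc(CNS(N)(=O)=O)c(F)c2)CC1`: 15.3 nM
Compound 3 `CN(C)C1(Cc2ccccc2)CCN(c2cc(C(F)(F)F)ccc2CNC(=O)Nc2cccc3c(=O)[nH]ccc23)CC1`: 111 nM

In an assay on CHO cells for displacement of a labelled ligand from transient receptor potential cation channel subfamily V member 1 (Homo sapiens), read by scintillation counting, with a stated time of 60 min (on this read-out lower numbers stand for stronger inhibition and higher numbers for weaker inhibition), compound 3 gives the highest number of the three, standing beyond the scatter from both compound 2 and compound 1, so among the measured compounds it is the weakest binder. Compound 4 `CN(C)C1(Cc2ccccc2)CCN(c2cc(C(F)(F)F)ccc2CNC(=O)Nc2cccc3ncccc23)CC1` arises from compound 3 by one change: a group of 10 heavy atoms (9 carbon, 1 nitrogen; one six-membered aromatic ring of carbon only, one six-membered aromatic ring with 1 hetero atom) in place of a group of 11 heavy atoms (9 carbon, 1 nitrogen, 1 oxygen; one six-membered aromatic ring of carbon only, one six-membered aromatic ring with 1 hetero atom), on an amide-type nitrogen. The group that leaves has no common name; the group that enters is quinolin-5-yl, and the hydrogen-bond donor of the leaving group is lost. Among the measured compounds shown here, no measured pair shows this change, so its direction is open. The step from compound 3 to compound 4 is expected to be a 1.4-fold higher number from compound 3 to compound 4 (0.13 log units; within the scatter), a modest move either way, possibly within the scatter. For compound 4 the estimate in this assay is 150 nM, with a range from 40 nM to 600 nM.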

Compound 4, inhibition constant: 10.8 nM
Compound 4: the middle estimate sits 14-fold (1.14 log units) above what was measured; the measured number lies below the stated range.
By their numbers in this assay, from the lowest: compound 1; then compounds 4 and 2 (each within the scatter of the next); then compound 3.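

In this assay, placing quinolin-5-yl on the amide-type nitrogen gives a 10-fold lower number from compound 3 to compound 4 (1.01 log units; beyond the scatter), the first single-change step available, and shows that the number is highly sensitive to the group at this place. The two groups have the same ring types and hydrogen-bond acceptor count, but the entering group lacks the oxygen, the double bond outside the aromatic rings and the hydrogen-bond donor. No available evidence bears on the reason for this step. The compounds shown do not separate the contributions of these differences. They also leave open how quinolin-5-yl carrying an amine would read in this assay.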